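Cyclopropylamino in place of dimethylamino on the carbonyl carbon

The source may report more compounds than this note shows. Statements on the series, on what has been measured and on what is new or still open speak of the compounds shown alone.

The three measured compounds share one core and differ in the group on the carbonyl carbon. In a functional assay on KB cells (Homo sapiens) for inhibition, read by sulforhodamine B assay, with a stated time of 72 h (a higher number here means a weaker inhibitor of growth, a lower number a stronger inhibitor of growth), compound 3 `CN(C)C(=O)/C=C/c1ccncc1-c1ccc2ccccc2c1` gives 7760 nM. Compound 2 `COC(=O)/C=C/c1ccncc1-c1ccc2ccccc2c1` gives 6730 nM. These two values lie close together, with a 1.2-fold higher number from compound 2 to compound 3 (0.06 log units; within the scatter). In this assay, compound 1 `CN1CCN(C(=O)/C=C/c2ccncc2-c2ccc3ccccc3c2)CC1` reads > 10000 nM, which is a limit of the assay and not a number. The steps out of that limit therefore give only floors, namely an at least 1.4-fold lower number from compound 1 to compound 2 (0.17 log units; that floor lies within the scatter) and an at least 1.2-fold lower number from compound 1 to compound 3 (0.11 log units; that floor lies within the scatter), and neither floor fixes a true size.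

Compound 4 `O=C(/C=C/c1ccncc1-c1ccc2ccccc2c1)NC1CC1` carries cyclopropylamino in place of dimethylamino on a carbonyl carbon. Among the measured compounds shown here, no measured compound carries an amide hydrogen, and no measured step covers that feature. For the measured compounds named here, the best guide is the one numeric step at this carbonyl carbon, where compound 3 stays close to compound 2, with a 1.2-fold higher number from compound 2 to compound 3 (0.06 log units; within the scatter). A change beyond the scatter is therefore not expected. The expected size of the change is a 1.1-fold lower number from compound 3 to compound 4 (0.04 log units; within the scatter). For compound 4 the estimated value in this assay is 7000 nM, with an expected range from 3000 nM to 10000 nM.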

Compound 4, concentration for 50% growth inhibition: 6050 nM
Beside the measured number, compound 4's estimate is 1.2-fold (0.06 log units) above it; the range from low to high includes it.
By their numbers in this assay, from the lowest: compounds 4, 2 and 3 (each within the scatter of the next). At a limit, above all of these: compound 1.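

In this assay, among the compounds shown here, cyclopropylamino brings the amide hydrogen and a three-membered ring to the carbonyl carbon, two features absent from the earlier compounds, yet the reading stays within the scatter of both numeric neighbours (a 1.3-fold lower number from compound 3 to compound 4 (0.11 log units; within the scatter); a 1.1-fold lower number from compound 2 to compound 4 (0.05 log units; within the scatter)). Methoxy, dimethylamino and cyclopropylamino therefore cannot be ordered at this position, and neither a hydrogen-bond donor on this carbonyl carbon nor the ring shows a measurable step on this evidence. Compound 1 gives > 10000 nM, which is a limit of the assay and not a number, so its step (an at least 1.6-fold lower number from compound 1 to compound 4 (0.21 log units; that floor lies within the scatter)) sets only a floor and shows no true size: (the limit of > 10000 nM in this assay, at which 1 of the 4 values shown sits).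

Since the amide hydrogen and the ring enter together, the step from compound 3 cannot separate them, and methylamino, with the hydrogen but no ring, or a tertiary amide such as azetidin-1-yl, with a ring but no hydrogen, would be needed to pull them apart. From the compounds shown here alone, what a carboxylic acid or a longer chain such as n-butylamino would read on this carbonyl carbon also remains open.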